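Trading Propargyl for 4-Bromobenzyl on the Shared Core

This account rests on a few compounds, and the source may have more. Where it says the series, first, only, none or still open, it means among the compounds named here.

Compound 3 `C#CCN(C(=O)/C=C/c1cc(OC)c(OC)c(OC)c1)C(=O)C(=C)C` gives > 10000 nM in a functional assay on LNCaP cells (Homo sapiens) for inhibition, read by WST assay, with a stated time of 48 h (on this read-out lower numbers stand for stronger inhibition of growth and higher numbers for weaker inhibition of growth), and that is a limit of the assay, not a number. In this assay, compound 1 `C=C(C)C(=O)N(Cc1cccc(Br)c1)C(=O)/C=C/c1cc(OC)c(OC)c(OC)c1` gives 10000 nM and compound 2 `C=C(C)C(=O)N(Cc1ccccc1C)C(=O)/C=C/c1cc(OC)c(OC)c(OC)c1` gives 10000 nM. Compound 4 `C=C(C)C(=O)N(Cc1ccc(Br)cc1)C(=O)/C=C/c1cc(OC)c(OC)c(OC)c1` carries 4-bromophenyl in place of ethynyl on a saturated chain carbon bound to an amide-type nitrogen. As far as these compounds go, the closest guides are a number no lower from compound 1 to compound 3 (the limit leaves the size open) and a number no lower from compound 2 to compound 3 (the limit leaves the size open), whose sizes stay open, together with no change at the digits printed from compound 1 to compound 2 (within the scatter). A small move toward a lower number, or none beyond the scatter, is therefore expected. The expected change is an at least 1.1-fold lower number from compound 3 to compound 4 (0.04 log units; that floor lies within the scatter). Compound 4 is estimated at 9000 nM, with a range from 3000 nM to 15000 nM.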

Compound 4, concentration for 50% growth inhibition: 7700 nM
For compound 4 the middle estimate is 1.2-fold (0.07 log units) above the measured one; the range from low to high includes it.
By their numbers in this assay, from the lowest: compounds 4, 1 and 2 (each within the scatter of the next).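

Trading propargyl for 4-bromobenzyl gives an at least 1.2-fold lower number from compound 3 to compound 4 (0.11 log units; that floor lies within the scatter), but compound 3 stands at a limit, so only a floor for this step can be read: the limit of > 10000 nM in this assay, at which 1 of the 4 values shown sits. Among the aromatic groups, the new compound adds two steps: a 1.3-fold lower number from compound 2 to compound 4 (0.11 log units; within the scatter) and a 1.3-fold lower number from compound 1 to compound 4 (0.11 log units; within the scatter). On a saturated chain carbon bound to an amide-type nitrogen, 4-bromophenyl, 3-bromophenyl and 2-methylphenyl are therefore not told apart in this assay. As far as these compounds go, whether an amine, a carboxylic acid or a longer chain at this place would move the number beyond the scatter stays open. From the compounds shown here alone, how far compound 3 lies past its limit also stays open.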